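The compounds below may be only part of what the source reports. "The series", "measured", "known", "first", "only" and "open" are said of these compounds alone.

Working notes on the series.

Compound 1 `COc1ccc(/C=C\c2cc(OC)c(OC)c(OC)c2)cc1OCc1ccc(CN2CC[C@H](C(=O)O)C2)cc1` carries a 3-carboxypyrrolidin-1-yl group on the saturated chain carbon bound to an aromatic carbon. In a functional assay on HeLa cells (Homo sapiens) for antiproliferative activity, read by CCK-8 assay, with a stated time of 48 h (on this read-out lower numbers stand for stronger inhibition and higher numbers for weaker inhibition), compound 1 gives only a limit, > 10000 nM. Compound 2 `COc1ccc(/C=C\c2cc(OC)c(OC)c(OC)c2)cc1OCc1ccc(CN2CC[C@H](O)C2)cc1` has hydroxy in place of carboxy on a saturated ring carbon; in this assay compound 2 gives 10500 nM. Compound 3 `COc1ccc(/C=C\c2cc(OC)c(OC)c(OC)c2)cc1OCc1ccc(CN2CC[C@@H](C(=O)O)C2)cc1` differs from compound 1 only in configuration (the two compounds have the same atoms and bonds and differ only in configuration as drawn: 1 of 2 stereo elements differ; a stereocentre at a saturated ring carbon is drawn S in compound 1 and R in compound 3); in this assay compound 3 gives 12800 nM. Compound 2 and compound 3 sit a 1.2-fold higher number from compound 2 to compound 3 (0.09 log units; within the scatter) apart, within the scatter, and the step that the limit leaves unreadable from compound 1 to compound 2 cannot be read because of the limit of > 10000 nM in this assay, at which 1 of the 3 values shown sits.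

Compound 4 `COc1ccc(/C=C\c2cc(OC)c(OC)c(OC)c2)cc1OCc1ccc(CN2CC[C@@H](O)C2)cc1` applies the same change to compound 3: hydroxy in place of carboxy on a saturated ring carbon. Its size cannot be taken from compound 1 to compound 2, so the expectation rests on compound 2 at 10500 nM and compound 3 at 12800 nM. Compound 4 is expected to move by a 1.1-fold lower number from compound 3 to compound 4 (0.05 log units; within the scatter) from compound 3. Compound 4 is estimated at 11500 nM, between 6000 nM and 25000 nM.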

Compound 4, half-maximal inhibitory concentration: > 10000 nM
Compound 4 ended at the assay's limit; the forecaster's own chance of this, stated with the estimate: 35%; the middle value lies beyond the limit too.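

In this assay compound 4 gives only a limit, > 10000 nM. For the compounds shown here, no step from compound 1, compound 2 or compound 3 to compound 4 can be read. The compounds shown leave open how far hydroxy in place of carboxy, or the configuration at the saturated ring carbon, moves the number.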